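Pyridin-3-yl for phenyl on the dienone side chain

The compounds below may be only part of what the source reports. "The series", "measured", "known", "first", "only" and "open" are said of these compounds alone.

Measured compounds and their numbers:
compound 1, `CC1=C(/C=C/C(=O)/C=C/c2ccccc2)C(C)(C)CCC1`: 12400 nM
compound 2, `CC1=C(/C=C/C(=O)/C=C/c2ccc(C)cc2)C(C)(C)CCC1`: 21500 nM
compound 3, `COc1ccc(/C=C/C(=O)/C=C/C2=C(C)CCCC2(C)C)cc1OC`: 30200 nM

In a functional assay on PC-3 cells (Homo sapiens) for cytotoxicity, read by sulforhodamine B assay, with a stated time of 48 h (on this read-out lower numbers stand for stronger inhibition and higher numbers for weaker inhibition), compound 1 stands at the low end of the three numbers. Compound 2 lies within the scatter of it, as the step of a 1.7-fold higher number from compound 1 to compound 2 (0.24 log units; within the scatter) shows. Among the compounds with values here, compound 3, with two methoxy groups on the aromatic ring, gives a number beyond the scatter from compound 1; no single-point step to it is available, so only the two values themselves can be compared.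

Compound 4, `CC1=C(/C=C/C(=O)/C=C/c2cccnc2)C(C)(C)CCC1`, is not yet measured. It differs from compound 1 by pyridin-3-yl in place of phenyl on a double-bonded chain carbon bound to a double-bonded chain carbon. Within the data shown here, no measured step of this kind exists; the one step at hand, from compound 1 to compound 2, changes only a substituent on the aromatic ring and stays within the scatter. Nothing in the measured compounds points to a step beyond the scatter in this assay in either direction, so the expectation for compound 4 is a number close to that of compound 1, with a wide range to cover the unknown.

Compound 4 is therefore estimated at 15000 nM, between 6000 nM and 40000 nM, which means an expected step of a 1.2-fold higher number from compound 1 to compound 4 (0.08 log units; within the scatter).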

Compound 4, half-maximal inhibitory concentration: 10200 nM
Beside the measured number, compound 4's estimate is 1.5-fold (0.17 log units) above it; low and high end bracket the measured number.
By their numbers in this assay, from the lowest: compounds 4, 1, 2 and 3 (each within the scatter of the next, the first and the last beyond it).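

In this assay, the swap of phenyl for pyridin-3-yl on a double-bonded chain carbon bound to a double-bonded chain carbon brings a hetero atom and a hydrogen-bond acceptor into the aromatic ring, and it gives a 1.2-fold lower number from compound 1 to compound 4 (0.08 log units; within the scatter), so this place accepts that ring nitrogen without a step that can be told from the scatter. Against the 4-methylphenyl group the same place gives a 2.1-fold lower number from compound 2 to compound 4 (0.32 log units; beyond the scatter), a modest step and the first one beyond the scatter between compounds that differ in one place, although the step of a 1.7-fold higher number from compound 1 to compound 2 (0.24 log units; within the scatter) stays within the scatter. Nothing available on these compounds accounts for either step, so the numbers stand here without an explanation.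

Still open, on these data alone, is whether an amine or a carboxylic acid on the pyridin-3-yl group, or a longer chain in its place, would move the number beyond the scatter from compound 4. The compounds shown also leave open whether any group at this place can reach numbers well below those seen so far, since all four lie close together.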